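A few compounds are considered here, and "the series" means these few. Any claim that something is new, unique, unknown or untested is made for them only; others in the source may bear on it.

In a functional assay on HeLa cells (Homo sapiens) for inhibition, with a stated time of 72 h (on this read-out lower numbers stand for stronger inhibition and higher numbers for weaker inhibition), the measured compounds are:
- compound 1 `NC1CCC(Nc2nc(NCc3ccc(-c4ccccc4)cc3)c3ncn(C4CCCC4)c3n2)CC1` at 240 nM 
- compound 2 `NC1CCC(Nc2nc(NCc3ccc(-c4ccco4)nc3)c3ncn(C4CCCC4)c3n2)CC1` at 30 nM 

Compound 2 holds the lower of the two numbers at 30 nM and sets the mark for the next change. Among the measured compounds shown here, the only measured step is an 8.0-fold lower number from compound 1 to compound 2 (0.90 log units; beyond the scatter) and it lies beyond the scatter.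

Compound 3 `NC1CCC(Nc2nc(NCc3cc(Cl)ccc3O)c3ncn(C4CCCC4)c3n2)CC1` is not yet measured. It carries 5-chloro-2-hydroxyphenyl in place of 6-(furan-2-yl)pyridin-3-yl on a saturated chain carbon bound to a nitrogen on an aromatic ring. Counted, the change reads 5-chloro-2-hydroxyphenyl in place of 6-(furan-2-yl)pyridin-3-yl on a saturated chain carbon bound to a nitrogen on an aromatic ring and no measured compound carries the entering group.

For the measured compounds named here, the sole guide is an 8.0-fold lower number from compound 1 to compound 2 (0.90 log units; beyond the scatter) as evidence that a swap at this place can move the number well beyond the scatter. A higher number of similar size is therefore expected, with a 6.7-fold higher number from compound 2 to compound 3 (0.82 log units; beyond the scatter) as the estimated step in this assay for now. For compound 3 the estimate is 200 nM with an expected range from 50 nM to 900 nM as the working figures.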

Compound 3, half-maximal inhibitory concentration: 750 nM
For compound 3 the middle estimate is 3.8-fold (0.57 log units) below the measured one; measured number inside the range.
By their numbers in this assay, from the lowest: compound 2; then compound 1; then compound 3.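

In this assay, the place on a saturated chain carbon bound to a nitrogen on an aromatic ring proves able to move the number in both directions: 5-chloro-2-hydroxyphenyl in place of 6-(furan-2-yl)pyridin-3-yl gives a 25-fold higher number from compound 2 to compound 3 (1.40 log units; beyond the scatter). The same group in place of 4-phenylphenyl gives a 3.1-fold higher number from compound 1 to compound 3 (0.49 log units; beyond the scatter), so both groups with two aromatic rings stand lower than this group with one. Among the compounds shown here, with only three compounds, ring count, the chlorine and the hydrogen-bond donor change together, and no measurement on hand explains the steps.

Open, on these data alone, is whether the single ring or its chloro and hydroxy substituents account for the higher number of compound 3. A plain phenyl group would help separate these, and 6-(thiophen-2-yl)pyridin-3-yl would test the furan ring in the best group so far.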